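This account rests on a few compounds, and the source may have more. Where it says the series, first, only, none or still open, it means among the compounds named here.

Compound 1 `CN(C(=O)c1ccc(Br)cc1)c1ccc2[nH]c(-c3n[nH]c4ccccc34)cc2n1` gives the lowest number of the three measured in a functional assay on KB cells (Homo sapiens) for antiproliferative activity, read by MTT assay, with a stated time of 72 h (on this read-out lower numbers stand for stronger inhibition and higher numbers for weaker inhibition), at 1780 nM. Going by the values given here, compound 2 `CN(C(=O)c1ccc([N+](=O)[O-])cc1)c1ccc2[nH]c(-c3n[nH]c4ccccc34)cc2n1` gives 20200 nM, and the one single-place step recorded, an 11-fold higher number from compound 1 to compound 2 (1.05 log units; beyond the scatter), is large. Among the compounds with values here, compound 3 `CN(C(=O)c1ccccc1)c1ccc2[nH]c(-c3n[nH]c4cc(C#N)ccc34)cc2n1` differs from compound 1 in two places; in this assay compound 3 gives 20900 nM; no single step is drawn for that pair. Compound 4 `CN(c1ccc2[nH]c(-c3n[nH]c4ccccc34)cc2n1)S(=O)(=O)c1ccc(Br)cc1` carries (4-bromophenyl)sulfonyl in place of (4-bromophenyl)carbonyl on a nitrogen on an aromatic ring. Within the data shown here, no measured step bears on a change at that nitrogen; the only recorded step concerns the substituent on the aromatic carbon, which is untouched here, and the shared core stays. The expected step is therefore small, a 1.8-fold higher number from compound 1 to compound 4 (0.25 log units; within the scatter), leaning toward a weaker value. For compound 4 the estimate in this assay is 3200 nM, with a range from 900 nM to 12000 nM.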

Compound 4, half-maximal inhibitory concentration: 7150 nM
Estimate against measurement, compound 4: 2.2-fold (0.35 log units) below; measured number inside the range.
By their numbers in this assay, from the lowest: compound 1; then compound 4; then compounds 2 and 3 (each within the scatter of the next).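

At a nitrogen on an aromatic ring, the linking group matters with the 4-bromophenyl part held constant: in this assay, (4-bromophenyl)sulfonyl in place of (4-bromophenyl)carbonyl gives a 4.0-fold higher number from compound 1 to compound 4 (0.60 log units; beyond the scatter). Going by these compounds alone, the earlier step covered only the substituent on an aromatic carbon, so this is the first reading of a change at this nitrogen. No available data explain the weaker value.

Still open, as far as these compounds go, is how a methylene link would compare with carbonyl and sulfonyl. Also open, from the compounds shown here alone, is whether the sulfonyl step persists with an amine in place of bromo.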